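Deca-1,4-dien-1-yl to octyl on two related cores

The compounds below may be only part of what the source reports. "The series", "measured", "known", "first", "only" and "open" are said of these compounds alone.

Three compounds have been measured in a functional assay on MDA-MB-231 cells (Homo sapiens) for antiproliferative activity, read by MTT assay; on this read-out higher numbers stand for weaker inhibition and lower numbers for stronger inhibition:

Compound 1, `CCCCC/C=C\C/C=C\CCCCCCCc1cc(=O)c2c(O)c(C)c(O)cc2o1`: compound 1 gives 16100 nM.
Compound 2, `CCCCCCCCCCCCCCCc1cc(=O)c2c(O)c(C)c(O)cc2o1`: compound 2 gives 42800 nM.
Compound 3, `CCCCC/C=C\C/C=C\CCCCCCCc1cc(=O)c2c(O)cc(OCOC)c(C)c2o1`: compound 3 gives 16100 nM.

Compound 1 and compound 2 share a core and differ in a single place: octyl in place of deca-1,4-dien-1-yl on a saturated chain carbon, seven bonds along the chain from an aromatic carbon. In this assay that change produced a 2.7-fold higher number from compound 1 to compound 2 (0.42 log units; beyond the scatter), a modest weakening that is nonetheless larger than the usual scatter of repeated measurements.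

Compound 3 carries the same long chain as compound 1 on a different core; the difference between the two cores is not broken down here. Its value sits level with that of compound 1, and the two together give the lowest numbers of the three measured compounds, with compound 2 the furthest away.

Compound 4, `CCCCCCCCCCCCCCCc1cc(=O)c2c(O)cc(OCOC)c(C)c2o1`, has not yet been measured. It relates to compound 3 exactly as compound 2 relates to compound 1: octyl in place of deca-1,4-dien-1-yl on a saturated chain carbon, seven bonds along the chain from an aromatic carbon. Since both "place" descriptions are identical, this is the same change, seen for the second time across the set.

Within the data shown here, for compound 4 the expected step is a 2.7-fold higher number from compound 3 to compound 4 (0.43 log units; beyond the scatter), resting on the one earlier example, because compound 1 to compound 2 showed a 2.7-fold higher number from compound 1 to compound 2 (0.42 log units; beyond the scatter). On these data alone, whether the new core responds in the same way is unknown, so the range is kept wide. The estimate for compound 4 is 43000 nM, between 20000 nM and 95000 nM.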

Compound 4, half-maximal inhibitory concentration: > 87000 nM
Compound 4 gave a limit, no number; the forecaster's own chance of this, stated with the estimate: 10%; at least 2.0-fold (0.30 log units) between middle value and limit.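

In this assay compound 4 gives > 87000 nM, which is a limit of the assay and not a number. Putting octyl in place of deca-1,4-dien-1-yl on the core of compound 3 gives an at least 5.4-fold higher number from compound 3 to compound 4 (0.73 log units; beyond the scatter), so the change weakens inhibition on this core as it does on the core of compound 1. The direction of the step therefore carries over from one core to the other, but its size on the second core stays unsettled, and two cores are too few to support a rule for the whole series: the same change on two cores in this assay, a 2.7-fold higher number (0.42 log units; beyond the scatter) from compound 1 to compound 2 and an at least 5.4-fold higher number (0.73 log units; beyond the scatter) from compound 3 to compound 4; the limit leaves it open whether they differ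

The compounds shown leave open how far the true value of compound 4 lies from its limit, and so whether the step is really larger on this core or about the same. They also leave open what other chains would do at this place, such as a chain with a single double bond, a shorter chain, or a chain ending in a carboxylic acid or an amine.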